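The source may report more compounds than this note shows. Statements on the series, on what has been measured and on what is new or still open speak of the compounds shown alone.

Measured compounds:
compound 1, `CC1CN(C(=O)c2ccc(-c3ccc(NC(=O)Nc4ccc(Cl)c(C(F)(F)F)c4)cc3)cc2)CC(C)O1`; compound 2, `O=C(/C=C/c1ccc(NC(=O)Nc2ccc(Cl)c(C(F)(F)F)c2)cc1)NC1CCC1`; compound 3, `CC(NC(=O)/C=C/c1ccc(NC(=O)Nc2ccc(Cl)c(C(F)(F)F)c2)cc1)c1ccccc1`

In a functional assay on MX1 cells (Homo sapiens) for inhibition, read by MTT assay, with a stated time of 120 h (on this read-out lower numbers stand for stronger inhibition and higher numbers for weaker inhibition), compound 2 gives 4530 nM and compound 3 gives 3130 nM. For compound 1 this assay reports only a limit, > 50000 nM. Among the measured compounds shown here, compound 2 thus stands at the highest of the two plain numbers, with compound 3 nearest; the one measured step, a 1.4-fold lower number from compound 2 to compound 3 (0.16 log units; within the scatter), lies within the scatter and concerns the amide-type nitrogen only.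

Compound 4, `CNC(=O)c1cccc(-c2ccc(NC(=O)Nc3ccc(Cl)c(C(F)(F)F)c3)cc2)c1`, differs from compound 2 in one place: 3-(methylcarbamoyl)phenyl in place of 2-(cyclobutylcarbamoyl)ethenyl on an aromatic carbon. For the measured compounds named here, no measured step matches this change; the pair of compound 1 and compound 2 differs in more than one place, so their two values show only that the biaryl amide of compound 1 sits at the limit of > 50000 nM in this assay, at which 1 of the 3 values shown sits, while compound 2 gives a plain number. The step from compound 2 to compound 3 gives no guidance on the present change. Compound 4 is therefore expected to sit at a higher number than compound 2, with a wide range, the expected step being a 3.3-fold higher number from compound 2 to compound 4 (0.52 log units; beyond the scatter). The estimate for compound 4 is 15000 nM, between 3000 nM and 60000 nM.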

Compound 4, half-maximal inhibitory concentration: > 50000 nM
Compound 4 ended at the assay's limit; the forecaster's own chance of this, stated with the estimate: 30%; at least 3.3-fold (0.52 log units) between middle value and limit.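

Among the compounds shown here, the change from 2-(cyclobutylcarbamoyl)ethenyl to 3-(methylcarbamoyl)phenyl, on an aromatic carbon para to a large group, gives the first measured step at this position in this assay and it is large: an at least 11-fold higher number from compound 2 to compound 4 (1.04 log units; beyond the scatter). From the compounds shown here alone, compound 4 gives only a limit, so the true size of this step remains unknown. The limit now holds a second compound: the limit of > 50000 nM in this assay, at which 2 of the 4 values shown sit.

The swap replaces the ethenyl link, the cyclobutyl group and the amide's place together, so the compounds shown do not separate what each part contributes. Also open, going by these compounds, is how a saturated ethyl link in place of the ethenyl, or a carboxylic acid or an amine in place of the amide, would read in this assay.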